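Swapping a Hydroxylated Branch for a Cyclopentenyl Ring

The source may report more compounds than this note shows. Statements on the series, on what has been measured and on what is new or still open speak of the compounds shown alone.

In an assay (Equus caballus) for inhibition of Thromboxane-A synthase (Homo sapiens), using microsomes (a higher number here means a weaker inhibitor, a lower number a stronger inhibitor), compound 2 `CC(C)(O)C(CCC/C=C(\c1ccccc1)c1cccnc1)C(=O)O` gives 42 nM, the largest of the two numbers measured; the nearest is compound 1 `C=C(C)C(CCC/C=C(\c1ccccc1)c1cccnc1)C(=O)O`, which gives 28 nM in this assay, with the step of a 1.5-fold higher number from compound 1 to compound 2 (0.18 log units; within the scatter). Compound 3 `O=C(O)C(CCC/C=C(\c1ccccc1)c1cccnc1)C1=CCCC1` differs from compound 2 by cyclopent-1-en-1-yl in place of 1-hydroxy-1-methylethyl on a saturated chain carbon bound to a carbonyl carbon and a saturated chain carbon. Among the measured compounds shown here, only that earlier step bears on this change, and it stayed within the scatter, so a changed branch at this place has so far moved this assay little. For compound 3 a step of a 1.4-fold lower number from compound 2 to compound 3 (0.15 log units; within the scatter) is therefore expected, with an estimate of 30 nM and a range from 10 nM to 90 nM.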

Compound 3, half-maximal inhibitory concentration: 60 nM
The estimate for compound 3 lay 2.0-fold (0.30 log units) below the measured number; measured number inside the range.
By their numbers in this assay, from the lowest: compounds 1, 2 and 3 (each within the scatter of the next, the first and the last beyond it).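

In this assay, cyclopent-1-en-1-yl in place of 1-hydroxy-1-methylethyl gives a 1.4-fold higher number from compound 2 to compound 3 (0.15 log units; within the scatter), so a branch with a hydrogen-bond donor and acceptor and a carbon-only ring without either cannot be told apart here. Among the compounds shown here, the same ring in place of 1-methylethenyl gives a 2.1-fold higher number from compound 1 to compound 3 (0.33 log units; beyond the scatter), the only step at this position so far that passes the scatter, and a modest one. No available evidence explains this step. From the compounds shown here alone, it remains open how an amine, a cyclohexenyl ring or a longer chain on this saturated chain carbon would fare.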